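The source may report more compounds than this note shows. Statements on the series, on what has been measured and on what is new or still open speak of the compounds shown alone.

Three compounds have been measured in a functional assay on MCF7 cells (Homo sapiens) for antiproliferative activity, read by CCK-8 assay, with a stated time of 72 h; on this read-out lower numbers stand for stronger inhibition and higher numbers for weaker inhibition:

Compound 1 `Cc1ccc(C(=O)Nc2cccc(-c3oc4cc(-c5ccc(F)cc5)ccc4c(=O)c3O)c2)cc1`: 2400 nM
Compound 2 `O=C(Nc1cccc(-c2oc3cc(-c4ccc(F)cc4)ccc3c(=O)c2O)c1)c1ccc(Cl)cc1`: 4730 nM
Compound 3 `O=C(Nc1cccc(-c2oc3cc(-c4ccc(F)cc4)ccc3c(=O)c2O)c1)c1cccc(F)c1`: 5770 nM

All three share one core and differ only in the group on the carbonyl carbon of the amide. Compound 2 sits in the middle of this small set: its step from compound 1 is a 2.0-fold higher number from compound 1 to compound 2 (0.29 log units; within the scatter), and its step to compound 3 is a 1.2-fold higher number from compound 2 to compound 3 (0.09 log units; within the scatter), so compound 2 cannot be told apart from either neighbour. Among the measured compounds shown here, only the step of a 2.4-fold higher number from compound 1 to compound 3 (0.38 log units; beyond the scatter) reaches beyond the scatter, and even that is modest.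

Compound 4 `COc1cc(OC)cc(C(=O)Nc2cccc(-c3oc4cc(-c5ccc(F)cc5)ccc4c(=O)c3O)c2)c1` has not yet been measured. It arises from compound 2 by the change (3,5-dimethoxyphenyl in place of 4-chlorophenyl on a carbonyl carbon). For the measured compounds named here, no measured step involves a 3,5-dimethoxyphenyl group, so the closest guides are the changes of the aromatic group already seen, each of which moved the number little. The step of a 1.1-fold higher number from compound 2 to compound 4 (0.02 log units; within the scatter) is therefore expected to stay within the scatter, with no firm direction. For compound 4 the expected value in this assay is 5000 nM, with a range from 2000 nM to 12500 nM.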

Compound 4, half-maximal inhibitory concentration: 3470 nM
The estimate for compound 4 lay 1.4-fold (0.16 log units) above the measured number; the measured number falls inside the stated range.
By their numbers in this assay, from the lowest: compounds 1, 4, 2 and 3 (each within the scatter of the next, the first and the last beyond it).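

In this assay, 3,5-dimethoxyphenyl in place of 4-chlorophenyl on the carbonyl carbon brings more heavy atoms and two hydrogen-bond acceptors, yet the step is small: a 1.4-fold lower number from compound 2 to compound 4 (0.13 log units; within the scatter). Among the compounds shown here, the other two steps also stay within the scatter, a 1.7-fold lower number from compound 3 to compound 4 (0.22 log units; within the scatter) and a 1.4-fold higher number from compound 1 to compound 4 (0.16 log units; within the scatter), so compound 4 cannot be told apart from any of the earlier compounds, whose phenyl rings each carry a single group. This position therefore accepts two methoxy groups on the phenyl ring with no readable change in the number, although nothing measured here gives a reason for this.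

All four compounds keep a phenyl ring on this carbonyl carbon. Going by these compounds, whether a saturated cyclohexyl ring, or a phenyl ring carrying an amine or a carboxylic acid, would move the number beyond the scatter remains open.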